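Shortening the Chain on the Ring Nitrogen

This account rests on a few compounds, and the source may have more. Where it says the series, first, only, none or still open, it means among the compounds named here.

Of the compounds shown here, three that share one core have been tested in a functional assay on HCT-116 cells (Homo sapiens) for cytotoxicity, read by MTT assay, with a stated time of 24 h; on this read-out higher numbers stand for weaker inhibition and lower numbers for stronger inhibition. Within the data shown here, compound 3 `CCCCn1cc(C(=O)OCC)c(=O)c2ccc(Cl)cc21` gives 39800 nM in this assay, the only actual number among the three results. Compound 1 `C=CCn1cc(C(=O)OCC)c(=O)c2ccc(Cl)cc21` gives > 50000 nM in this assay, which is a limit of the assay rather than a number. Compound 2 `CCOC(=O)c1cn(C)c2cc(Cl)ccc2c1=O` gives > 50000 nM in this assay, again a limit. Compound 4 `CCOC(=O)c1cn(CC)c2cc(Cl)ccc2c1=O` is not yet measured; it differs from compound 3 by hydrogen in place of ethyl on a saturated chain carbon, two bonds along the chain from an aromatic nitrogen, a change that, cut one bond further out, reads butyl to ethyl. Among the measured compounds shown here, two measured steps bear on it: an at least 1.2-fold lower number from compound 2 to compound 3 (0.09 log units; that floor lies within the scatter) and an at least 1.2-fold lower number from compound 1 to compound 3 (0.09 log units; that floor lies within the scatter). Going by these compounds, both rest on (the limit of > 50000 nM in this assay, at which 2 of the 3 values shown sit), so their true size stays unknown, and their floors lie within the scatter. The remaining pair is a step that the two limits leave unreadable from compound 1 to compound 2. The chain of compound 4 is shorter than that of compound 3 and longer than that of compound 2, so its value is expected to fall at or near the limit, with a 1.3-fold higher number from compound 3 to compound 4 (0.10 log units; within the scatter) as the expected step. Compound 4 is therefore estimated at 50000 nM, with a range from 25000 nM to 100000 nM.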

Compound 4, half-maximal inhibitory concentration: > 50000 nM
Compound 4: no number, only a limit (the forecaster's own chance of this, stated with the estimate: 60%); the middle value sits exactly at the limit.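

Trimming the chain from butyl to ethyl, on a saturated chain carbon two bonds along the chain from an aromatic nitrogen, gives in this assay an at least 1.2-fold higher number from compound 3 to compound 4 (0.09 log units; that floor lies within the scatter). Among the chains shown, butyl is now the only one that yields an actual number, while the ethyl chain joins the shorter methyl chain and the unsaturated chain of compound 1 at the limit, so any benefit of the butyl chain rests on a single value and its true size remains unknown. The steps to compound 4 from compound 1 and from compound 2 cannot be read, because each of them joins two limits: the limit of > 50000 nM in this assay, at which 3 of the 4 values shown sit.

Going by these compounds, it remains open whether a longer chain, such as hexyl, would carry the number clearly beyond the scatter, or whether an amine or a carboxylic acid at the end of the butyl chain would change the result at this position. Nor can the compounds shown tell how compound 1, compound 2 and compound 4 rank against one another, as none of the three has a number.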